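The source may report more compounds than this note shows. Statements on the series, on what has been measured and on what is new or still open speak of the compounds shown alone.

Measured compounds:
compound 1, `COc1ccc(-c2c(C#N)c(N)c(C#N)c(SC)c2-c2ccc(F)cc2)cc1`: 5.5%
compound 2, `CSc1c(C#N)c(N)c(C#N)c(C)c1-c1ccc(F)cc1`: 41.8%

In an assay on isolated protein for inhibition of glucose-6-phosphatase catalytic subunit 1 (Homo sapiens), tested at 100 uM (on this read-out higher numbers stand for more inhibition at the one concentration tested (going by the name of the read-out) and lower numbers for less inhibition), compound 1 gives 5.5%, the lowest of the two numbers shown, and the only measured step is a number 36.3 percentage points higher from compound 1 to compound 2 (beyond the scatter), a large change. Compound 3, `COc1ccc(-c2c(C)c(SC)c(C#N)c(N)c2C#N)cc1`, is not yet measured; it differs from compound 1 by methyl in place of 4-fluorophenyl on an aromatic carbon. That measured step also puts methyl in place of a group containing a six-membered aromatic ring of carbon only on the same core, so it bears directly on compound 3. A step of a number 29.5 percentage points higher from compound 1 to compound 3 (beyond the scatter) is therefore expected. Compound 3 is estimated to give about 35%, within a range from 10% to 60%.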

Compound 3, a percentage reported as inhibition, at one concentration (the size of the read-out at that concentration, not a potency): 12.3%
For compound 3 the middle estimate is 22.7 percentage points above the measured one; the measured number falls inside the stated range.
By their numbers in this assay, from the lowest: compounds 1 and 3 (each within the scatter of the next); then compound 2.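

In this assay, replacing 4-fluorophenyl with methyl gives a number 6.8 percentage points higher from compound 1 to compound 3 (within the scatter), so removing this aromatic ring leaves no change that can be told from scatter. A similar replacement of 4-methoxyphenyl gave a number 36.3 percentage points higher from compound 1 to compound 2 (beyond the scatter), so the effect of methyl depends on which of the two rings it replaces. No measured information here explains that contrast.

The compounds shown leave open how an amine, a carboxylic acid or a longer chain would read at this position in place of methyl.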